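Acrylamide series notes: from compound 1 toward compound 4

The source may hold more compounds than are shown below. What is called first, only, known or untested is meant among the compounds shown, and "the series" means these compounds.

Compound 1 `N#C/C(=C\c1ccc[nH]1)C(=O)NCc1ccc(Cl)c(Cl)c1` stands at a limit in a functional assay on SW480 cells (Homo sapiens) for inhibition, read by MTT assay, with a stated time of 72 h; a lower number here means a stronger inhibitor of growth, a higher number a weaker inhibitor of growth: compound 1 gives > 50000 nM, which is a limit of the assay and not a number, matching (the limit of > 50000 nM in this assay, at which 1 of the 3 values shown sits). Compound 2 `COc1ccc(CNC(=O)/C(C#N)=C/c2cc(Br)co2)cc1` also stops at a limit, giving > 100000 nM in this assay, which is the limit of > 100000 nM in this assay, at which 1 of the 3 values shown sits. Only compound 3 `COc1ccc(CNC(=O)/C(C#N)=C/c2ccc3ccccc3c2)cc1` yields a number, 41000 nM in this assay. Within the data shown here, no step between measured compounds is available. Compound 4 `N#C/C(=C\c1ccc(Cl)cc1)C(=O)NCc1ccc(Cl)c(Cl)c1` differs from compound 1 by 4-chlorophenyl in place of 1H-pyrrol-2-yl on a double-bonded chain carbon bound to a double-bonded chain carbon. For this assay the expected step is small, at most a move from where compound 1 stands toward a measurable value near that of compound 3, and a readout of the same kind as that of compound 1 is quite possible for compound 4. The estimate for compound 4 is 40000 nM, range 15000 nM to 120000 nM, with the step of an at least 1.2-fold lower number from compound 1 to compound 4 (0.09 log units; that floor lies within the scatter) expected.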

Compound 4, concentration for 50% growth inhibition: 30000 nM
Compound 4: middle estimate off by 1.3-fold (0.12 log units), on the high side; low and high end bracket the measured number.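

In this assay, among these compounds, 4-chlorophenyl in place of 1H-pyrrol-2-yl on this double-bonded chain carbon gives the first one-place comparison and turns a limit into a number, with an at least 1.6-fold lower number from compound 1 to compound 4 (0.22 log units; that floor lies within the scatter). Compound 1 stays a limit and not a number: the limit of > 50000 nM in this assay, at which 1 of the 4 values shown sits. The step is therefore only a floor, and its true size cannot be read.

From the compounds shown here alone, it remains open whether the chlorine or the loss of the pyrrole nitrogen-hydrogen matters more. A plain phenyl, 4-carboxyphenyl or 4-(dimethylamino)phenyl at this place would separate these readings.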